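A few compounds are considered here, and "the series" means these few. Any claim that something is new, unique, unknown or untested is made for them only; others in the source may bear on it.

Measured compounds:
Compound 1, `CCOC(=O)N1CCN(CCC(=O)O[C@@H]2C[C@@H]3CC[C@@]2(C)C3(C)C)CC1`, gives 150000 nM in an ADME assay on MDCK cells (Canis lupus familiaris) for cytotoxicity, read by MTT assay, with a stated time of 48 h; on this read-out higher numbers stand for lower toxicity in this test and lower numbers for higher toxicity in this test.
Compound 2, `CCCCN(CCCC)CCC(=O)O[C@@H]1C[C@@H]2CC[C@@]1(C)C2(C)C`, gives 41800 nM in this assay.

Among the measured compounds shown here, of the two numbers, compound 1 stands highest, meaning the least toxic in this test; its only neighbour, compound 2, sits at a lower number, and that gap lies beyond the usual scatter. Compound 3, `CCN1CCN(CCC(=O)O[C@@H]2C[C@@H]3CC[C@@]2(C)C3(C)C)CC1`, has not yet been measured in this assay. It differs from compound 1 in a single place: ethyl in place of ethoxycarbonyl on an amine nitrogen in a ring. For the measured compounds named here, no step between two measured compounds covers this change, so its size is uncertain. Both measured compounds share the same core and differ only in the amine part, and compound 2 gives the lower number. For compound 3 the number is expected to move downward from compound 1 by a moderate step, a 1.9-fold lower number from compound 1 to compound 3 (0.27 log units; within the scatter), with a result within the scatter of compound 1 still possible. Compound 3 is therefore estimated at 80000 nM, in the range 30000 nM to 200000 nM.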

Compound 3, half-maximal cytotoxic concentration: 105000 nM
Compound 3: the middle estimate sits 1.3-fold (0.12 log units) below what was measured, and the stated range covers the measured number.
By their numbers in this assay, from the lowest: compound 2; then compounds 3 and 1 (each within the scatter of the next).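

On the amine nitrogen in the six-membered ring, ethyl in place of ethoxycarbonyl gives a 1.4-fold lower number from compound 1 to compound 3 (0.15 log units; within the scatter) in this assay and this step stays within the usual scatter of repeated measurements. The change is not small in structure, since ethoxycarbonyl, with 5 heavy atoms, 1 double bond and 2 hydrogen-bond acceptors, gives way to ethyl, with 2 heavy atoms and no hydrogen-bond acceptors, yet the two compounds cannot be told apart in this test. No measurement at hand offers an explanation for this result.

Still open, from the compounds shown here alone, is whether a different group on this nitrogen, such as benzyl, acetyl or a longer carbon chain, would move the number beyond the scatter. Also open, going by these compounds, is whether swapping ethoxycarbonyl for ethyl would give a similar result on a different core.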